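This account rests on a few compounds, and the source may have more. Where it says the series, first, only, none or still open, it means among the compounds named here.

Three esters that share one core have been measured in an ADME assay on cells (Hepatocyte, Mus musculus) for metabolic stability; on this read-out lower numbers stand for a shorter-lived compound and higher numbers for a longer-lived compound. Compound 1 `O=C(OC1CCC(CN2CCN(c3cc(=O)c4cc(C(F)(F)F)cc([N+](=O)[O-])c4s3)CC2)CC1)C1CCCCC1` carries a cyclohexyl group on the carbonyl carbon, and in this assay compound 1 gives 0.0783 h. Compound 2 `O=C(OC1CCC(CN2CCN(c3cc(=O)c4cc(C(F)(F)F)cc([N+](=O)[O-])c4s3)CC2)CC1)c1ccc(F)cc1` has a 4-fluorophenyl group there instead, and compound 2 gives 0.0817 h. Compound 3 `Cc1ccc(C(=O)OC2CCC(CN3CCN(c4cc(=O)c5cc(C(F)(F)F)cc([N+](=O)[O-])c5s4)CC3)CC2)cc1` carries a 4-methylphenyl group, and compound 3 gives 0.202 h, the highest of the three numbers. The step of a 1.0-fold higher number from compound 1 to compound 2 (0.02 log units; within the scatter) changes nothing that can be trusted, whereas a 2.6-fold higher number from compound 1 to compound 3 (0.41 log units; beyond the scatter) and a 2.5-fold higher number from compound 2 to compound 3 (0.39 log units; beyond the scatter) are both modest but real.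

Compound 4 `O=C(OC1CCC(CN2CCN(c3cc(=O)c4cc(C(F)(F)F)cc([N+](=O)[O-])c4s3)CC2)CC1)c1ccc(C(F)(F)F)cc1` has not yet been measured. Going by the values given here, its only difference from compound 3 is trifluoromethyl in place of methyl on an aromatic carbon. Among the compounds with values here, no measured step exchanges methyl for trifluoromethyl, so the closest guidance comes from the fact that changing the group on this aromatic carbon, as in a 2.5-fold higher number from compound 2 to compound 3 (0.39 log units; beyond the scatter), moved the number only modestly. On that basis the expected step is a 1.0-fold lower number from compound 3 to compound 4 (0.00 log units; within the scatter), which would leave compound 4 close to compound 3 and not clearly beyond the scatter. The estimate for compound 4 in this assay is therefore 0.2 h, with a range from 0.08 h to 0.5 h.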

Compound 4, half-life: 0.278 h
Compound 4: middle estimate off by 1.4-fold (0.14 log units), on the low side, and the stated range covers the measured number.
By their numbers in this assay, from the lowest: compounds 1 and 2 (each within the scatter of the next); then compounds 3 and 4 (each within the scatter of the next).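

In this assay, putting trifluoromethyl on this aromatic carbon (a 1.4-fold higher number from compound 3 to compound 4 (0.14 log units; within the scatter)) shows that four heavy atoms can replace the single carbon of methyl with no change that can be told from ordinary scatter, so compounds 3 and 4 cannot be ranked against each other. The higher number of compound 3 is therefore not unique to methyl, since compound 4 also stands clearly apart from the fluoro compound (a 3.4-fold higher number from compound 2 to compound 4 (0.53 log units; beyond the scatter)) and from the cyclohexyl compound (a 3.6-fold higher number from compound 1 to compound 4 (0.55 log units; beyond the scatter)), although each of these steps is only modest. Nothing measured here explains why methyl and trifluoromethyl group together while fluoro falls with cyclohexyl.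

Going by these compounds alone, with only three groups compared on this aromatic carbon, it remains open whether the grouping holds for other substituents, such as an amine, a carboxylic acid, a methoxy group or a longer alkyl chain, or for plain hydrogen. Going by these compounds, it is also open whether any change on this ring can carry the number much further, or whether replacing the ester with an amide would matter more.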